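Acetylation of the morpholine on the amide side chain

The source may hold more compounds than are shown below. What is called first, only, known or untested is meant among the compounds shown, and "the series" means these compounds.

Three compounds share a core and differ only in the group on the amide-type nitrogen. Compound 1 `Cn1ccc2ccc(-c3cc(Nc4cnccc4C(=O)NCc4cncnc4)cc4nccnc34)cc21` carries a (pyrimidin-5-yl)methyl group and gives 106 nM in an assay for inhibition of 6-phosphofructo-2-kinase/fructose-2,6-bisphosphatase 3 (Homo sapiens), read by ADP-Glo, with a stated time of 2 h; a lower number here means a stronger inhibitor, a higher number a weaker inhibitor. Compound 2 `Cn1cc(NC(=O)c2ccncc2Nc2cc(-c3ccc4ccn(C)c4c3)c3nccnc3c2)cn1` bears 1-methyl-1H-pyrazol-4-yl directly on that nitrogen and gives 33 nM in this assay. Compound 3 `Cn1ccc2ccc(-c3cc(Nc4cnccc4C(=O)NCC4COCCN4)cc4nccnc34)cc21` carries (morpholin-3-yl)methyl and gives 33 nM in this assay. Compound 3 stands level with compound 2, the two together being the lowest of the three numbers; a 3.2-fold lower number from compound 1 to compound 3 (0.51 log units; beyond the scatter), while no change at the digits printed from compound 2 to compound 3 (within the scatter).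

Compound 4 `CC(=O)N1CCOC(CNC(=O)c2ccncc2Nc2cc(-c3ccc4ccn(C)c4c3)c3nccnc3c2)C1` has not yet been measured. Its change relative to compound 3 is 4-acetylmorpholin-2-yl in place of morpholin-3-yl on a saturated chain carbon bound to an amide-type nitrogen. Of the steps seen so far, the two that bear on it are the one from the pyrimidine to the morpholine, a 3.2-fold lower number from compound 1 to compound 3 (0.51 log units; beyond the scatter), and the one from the pyrazole to the morpholine, no change at the digits printed from compound 2 to compound 3 (within the scatter). Among the measured compounds shown here, both show the amide substituent changing by a modest amount at most, and no measured step tells how acetylating the morpholine nitrogen or moving the attachment point within the ring acts.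

He therefore expects compound 4 to stay close to compound 3, with a 1.4-fold higher number from compound 3 to compound 4 (0.13 log units; within the scatter) as an estimate, and no step beyond the scatter. His estimate for compound 4 in this assay is 45 nM, within 15 nM to 140 nM.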

Compound 4, half-maximal inhibitory concentration: 93 nM
Beside the measured number, compound 4's estimate is 2.1-fold (0.32 log units) below it; low and high end bracket the measured number.
By their numbers in this assay, from the lowest: compounds 2 and 3 (each within the scatter of the next); then compounds 4 and 1 (each within the scatter of the next).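

In this assay, the group on a saturated chain carbon bound to an amide-type nitrogen proves sensitive to a change within the saturated ring itself: there is a 2.8-fold higher number from compound 3 to compound 4 (0.45 log units; beyond the scatter), and also a 2.8-fold higher number from compound 2 to compound 4 (0.45 log units; beyond the scatter), so a morpholine ring on this chain does not by itself hold the lower level. The remaining comparison, a 1.1-fold lower number from compound 1 to compound 4 (0.06 log units; within the scatter), puts the (4-acetylmorpholin-2-yl)methyl group level with the (pyrimidin-5-yl)methyl group, and the gain seen earlier with (morpholin-3-yl)methyl does not carry over to it. Among the compounds shown here, the single step combines a new attachment point on the ring, an added acetyl group and a move from 1 hydrogen-bond donor to 0, and nothing measured here accounts for the loss or assigns it to any one of these.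

On these data alone, what stays open is which part of the change carries the step, since a free morpholin-2-yl group and a 4-acetylmorpholin-3-yl group on the same chain would separate the attachment point from the acetylation. Also open, as far as these compounds go, is whether the effect belongs to the acetyl group in particular or to any substituent on the ring nitrogen, a question that a 4-methyl group or a methanesulfonyl group there would address.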